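Dropping the benzyl group from a coumarin propargylamine

The source may report more compounds than this note shows. Statements on the series, on what has been measured and on what is new or still open speak of the compounds shown alone.

Compound 3, `C#CCN(CCCOc1ccc2ccc(=O)oc2c1)Cc1ccc(OC)cc1`, gives 60000 nM in an ADME assay on isolated protein for inhibition of Amine oxidase [flavin-containing] A (Homo sapiens), read by fluorescence and Amplex Red, with stated times of 15 min and 20 min; on this read-out higher numbers stand for weaker inhibition and lower numbers for stronger inhibition. Within the data shown here, that is the highest of the three numbers measured so far, but the gap to compound 1, `C#CCN(CCCOc1ccc2ccc(=O)oc2c1)Cc1ccccc1`, with 38600 nM, lies within the scatter, while the gap to compound 2, `C#CCN(CCCOc1ccc2ccc(=O)oc2c1)Cc1cccc(F)c1`, with 29300 nM, is a 2.0-fold higher number from compound 2 to compound 3 (0.31 log units; beyond the scatter). Compound 4, `C#CCN(C)CCCOc1ccc2ccc(=O)oc2c1`, has not been measured. It differs from compound 3 by hydrogen in place of 4-methoxyphenyl on a saturated chain carbon bound to an amine nitrogen.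

Among the measured compounds shown here, none of the measured steps bears directly on this change. The steps of a 1.3-fold lower number from compound 1 to compound 2 (0.12 log units; within the scatter) and a 1.6-fold higher number from compound 1 to compound 3 (0.19 log units; within the scatter) only swap small groups on the aromatic ring that is now removed, and both stay within the scatter; the step of a 2.0-fold higher number from compound 2 to compound 3 (0.31 log units; beyond the scatter) is modest. Together they show that what sits on that ring hardly moves the number, yet they say nothing about removing the ring itself. The direction is therefore open, and the estimate must carry a wide range. Compound 4 is expected to give roughly 45000 nM in this assay, between 8000 nM and 250000 nM, which means an expected step of a 1.3-fold lower number from compound 3 to compound 4 (0.12 log units; within the scatter).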

Compound 4, half-maximal inhibitory concentration: 36900 nM
For compound 4 the middle estimate is 1.2-fold (0.09 log units) above the measured one, within the range that was stated.
By their numbers in this assay, from the lowest: compounds 2, 4, 1 and 3 (each within the scatter of the next, the first and the last beyond it).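

In this assay the whole ring can go, with 4-methoxybenzyl cut back to methyl, and the number stays within the scatter of all three benzyl compounds (a 1.6-fold lower number from compound 3 to compound 4 (0.21 log units; within the scatter); a 1.3-fold higher number from compound 2 to compound 4 (0.10 log units; within the scatter); a 1.0-fold lower number from compound 1 to compound 4 (0.02 log units; within the scatter)). The earlier compounds showed only that small groups on the aromatic ring make little difference, whereas compound 4 shows that among these four compounds the ring itself makes no difference beyond the scatter either. Nothing available explains why the number holds once the ring is gone.

Still open, going by these compounds, is whether a group at this position that differs from both methyl and the benzyl groups, such as cyclohexylmethyl or 2-phenylethyl, would shift the number beyond the scatter. The same holds for a plain hydrogen in place of methyl, which would leave a secondary amine.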